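A few compounds are considered here, and "the series" means these few. Any claim that something is new, unique, unknown or untested is made for them only; others in the source may bear on it.

Of the compounds shown here, three sharing one core have been measured so far in a physicochemical assay for lipophilicity, measured as octanol-water partition (on this read-out higher numbers stand for higher lipophilicity and lower numbers for lower lipophilicity), on this scale. Compound 1 `CCN1C(=O)c2c(nc(C#Cc3ccccc3)n2Cc2ccc(OC)cc2)N2C1=N[C@@H]1CCC[C@@H]12` gives 5.5 and compound 2 `CCOc1nc2c(n1Cc1ccc(OC)cc1)C(=O)N(CC)C1=N[C@@H]3CCC[C@@H]3N12` gives 4.1 while compound 3 `CCN1C(=O)c2c(nc(C(=O)OC)n2Cc2ccc(OC)cc2)N2C1=N[C@@H]1CCC[C@@H]12` gives 3.38 in the same measurement. Compound 2 therefore stands second highest of the three, with gaps beyond the scatter on both sides. Compound 4 `CCOc1nc2c(n1Cc1ccc(OC)c(Br)c1)C(=O)N(CC)C1=N[C@@H]3CCC[C@@H]3N12` departs from compound 2 in one place: bromo in place of hydrogen on an aromatic carbon and so 4-methoxybenzyl becomes 3-bromo-4-methoxybenzyl. The measured steps all concern another place, the group that is ethoxy in compound 2. Of these, a number 1.40 log units lower from compound 1 to compound 2 (beyond the scatter) and a number 2.12 log units lower from compound 1 to compound 3 (beyond the scatter) were large while a number 0.72 log units lower from compound 2 to compound 3 (beyond the scatter) was modest. None of them puts bromo in place of hydrogen, so none measures this change directly, and the expectation rests on the change itself. A modest rise is expected, with a number 0.70 log units higher from compound 2 to compound 4 (beyond the scatter) as the estimated step. For compound 4 the estimated value is 4.8 with an expected range from 4.4 to 5.2 on this scale.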

Compound 4, partition coefficient: 4.93
The estimate for compound 4 lay 0.13 log units below the measured number; measured number inside the range.
By their numbers in this assay, from the lowest: compound 3; then compound 2; then compound 4; then compound 1.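

Going by these compounds alone, the step of a number 0.83 log units higher from compound 2 to compound 4 (beyond the scatter) in this assay is the first measured change on the benzyl group, whereas all the earlier steps concerned the group that is ethoxy in compound 2, so this aromatic carbon, ortho to a methoxy group, also moves the number beyond the scatter when a single bromo replaces hydrogen. This step is modest, the same grade as the step of a number 0.72 log units lower from compound 2 to compound 3 (beyond the scatter) at the other place, so both single changes made on compound 2 so far fall in that grade. Nothing available gives a reason for this step.

The compounds shown leave open what chloro, fluoro or methyl would do on this same carbon. They also leave open whether bromo gives a similar step when 2-phenylethynyl or methoxycarbonyl stands in place of ethoxy.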